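The source may report more compounds than this note shows. Statements on the series, on what has been measured and on what is new or still open speak of the compounds shown alone.

Compound 1 `COc1cccc(-c2nc3ccc(C)cc3c(=O)[nH]2)c1` and compound 2 `Cc1ccc2nc(-c3cccc(F)c3)[nH]c(=O)c2c1` share one core, while compound 3 `Cc1ccc2c(=O)[nH]c(-c3cccc(F)c3)nc2c1` has the same atoms joined differently; the difference between the two cores is not broken down here. In a functional assay on HCT-15 cells (Homo sapiens) for cytotoxicity, read by MTT assay, with a stated time of 2 days (a lower number here means a stronger inhibitor, a higher number a weaker inhibitor), compound 1 gives 32000 nM. Compound 2 reaches only > 50000 nM in this assay, which is a limit of the assay and not a number. The change methoxy in place of fluoro on an aromatic carbon thus gave an at least 1.5-fold lower number from compound 2 to compound 1 (0.19 log units; that floor lies within the scatter), a size known only as a floor because of the limit of > 50000 nM in this assay, at which 1 of the 3 values shown sits. Compound 3 gives 14400 nM in this assay. Compound 4 `COc1cccc(-c2nc3cc(C)ccc3c(=O)[nH]2)c1` is not yet measured; it carries the same change, (methoxy in place of fluoro on an aromatic carbon), on the core of compound 3. Compound 4 is expected to show a 1.6-fold lower number from compound 3 to compound 4 (0.20 log units; within the scatter) in this assay because an at least 1.5-fold lower number from compound 2 to compound 1 (0.19 log units; that floor lies within the scatter) on the other core. Compound 4 is therefore estimated at 9000 nM, likely between 3500 nM and 25000 nM.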

Compound 4, half-maximal inhibitory concentration: 4850 nM
The estimate for compound 4 lay 1.9-fold (0.27 log units) above the measured number, within the range that was stated.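

Putting methoxy in place of fluoro on the core of compound 3 gave a 3.0-fold lower number from compound 3 to compound 4 (0.47 log units; beyond the scatter) in this assay, so on this core the change has a size that stands clear of the scatter. Set beside the step on the other core, this does not show that the change carries over with the same size: the same change on two cores in this assay, an at least 1.5-fold lower number (0.19 log units; that floor lies within the scatter) from compound 2 to compound 1 and a 3.0-fold lower number (0.47 log units; beyond the scatter) from compound 3 to compound 4; the limit leaves it open whether they differ. Compound 2 gives > 50000 nM, which is a limit of the assay and not a number, so its step is known only as a floor: the limit of > 50000 nM in this assay, at which 1 of the 4 values shown sits.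

Still open, going by these compounds, is whether an amine or a longer chain such as ethoxy, in the place of methoxy, would move the number on either core. On these data alone, whether the step holds on other cell types is also open.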